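From Methyl to Bromo: An Expectation for Compound 4

The source may hold more compounds than are shown below. What is called first, only, known or untested is meant among the compounds shown, and "the series" means these compounds.

Measured so far:
compound 1 `Cc1cccc2cc(S(=O)(=O)NC(=O)Nc3ccc(Cl)cc3)oc12`: 21%
compound 2 `O=C(Nc1ccc(Cl)cc1)NS(=O)(=O)c1ccc2cc[nH]c2c1`: 37%
compound 3 `Cc1cc2cc(S(=O)(=O)NC(=O)Nc3ccc(Cl)cc3)ccc2o1`: 57%

Of the compounds shown here, three have been tested in a functional assay on the whole organism (Mus musculus) for inhibition, at a dose of 150 mg/kg by the oral route; on this read-out higher numbers stand for more inhibition at the one dose given (going by the name of the read-out) and lower numbers for less inhibition. Compound 1 stands lowest of the three numbers; compound 2 lies higher by more than the usual scatter, and compound 3 higher still, also beyond the scatter. Compound 4 `O=C(Nc1ccc(Cl)cc1)NS(=O)(=O)c1cc2cccc(Br)c2o1` has not yet been measured. It differs from compound 1 in one place: bromo in place of methyl on an aromatic carbon. Among the compounds with values here, no measured pair differs in just this way, so there is no measured step to lean on. Exchanging one small group for another is expected to shift the number only modestly, in either direction, most likely not beyond the scatter. Compound 4 is therefore expected to give about 28% in this assay, between 5% and 55%. For compound 4 this means an expected step of a number 7 percentage points higher from compound 1 to compound 4 (within the scatter).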

Compound 4, a percentage reported as inhibition, in the whole organism at one dose (the size of the read-out at that dose, not a potency): 18%
Beside the measured number, compound 4's estimate is 10 percentage points above it; measured number inside the range.
By their numbers in this assay, from the lowest: compounds 4 and 1 (each within the scatter of the next); then compound 2; then compound 3.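

In this assay the exchange of methyl for bromo on this aromatic carbon gives a small step (a number 3 percentage points lower from compound 1 to compound 4 (within the scatter)). Within this pair, the two groups therefore cannot be told apart at the one dose given, which the earlier compounds could not show, as none of them formed a pair differing in one place. Nothing measured here bears on why the two groups read alike. The compounds shown leave open whether a quite different group at this position, such as an amine or a carboxylic acid, would move the number beyond the scatter.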